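This account rests on a few compounds, and the source may have more. Where it says the series, first, only, none or still open, it means among the compounds named here.

Compound 1 `Cn1c(NN)nc(-c2ccco2)c(C#N)c1=O`: 58 ug/mL
Compound 2 `CCOC(=O)c1cnn(-c2nc(-c3ccc(OC)cc3)c(C#N)c(=O)n2C)c1N`: 74 ug/mL
Compound 3 `Cn1c(NN)nc(-c2ccccc2F)c(C#N)c1=O`: 49 ug/mL

These three compounds were tested in a functional assay, with a stated time of 10 min; on this read-out higher numbers stand for weaker inhibition and lower numbers for stronger inhibition. Compound 2 gives the largest of the three numbers, yet its gaps to compound 1 and to compound 3 both fall within the usual scatter of such measurements, so the three cannot be told apart on this read-out. Compound 4 `CCOC(=O)c1cnn(-c2nc(-c3ccc(N(C)C)cc3)c(C#N)c(=O)n2C)c1N` keeps the core of compound 2 and differs from it in a single place: dimethylamino in place of methoxy on an aromatic carbon. Among the compounds with values here, no measured pair shows what this change does, so the expectation rests on compound 2 alone. Compound 4 is expected to show only a small step, a 1.1-fold lower number from compound 2 to compound 4 (0.02 log units; within the scatter), in no clear direction beyond the scatter. Compound 4 is therefore estimated at 70 ug/mL, with a range from 30 ug/mL to 160 ug/mL.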

Compound 4, half-maximal inhibitory concentration: 119 ug/mL
For compound 4 the middle estimate is 1.7-fold (0.23 log units) below the measured one; low and high end bracket the measured number.
By their numbers in this assay, from the lowest: compounds 3, 1, 2 and 4 (each within the scatter of the next, the first and the last beyond it).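

In this assay, dimethylamino in place of methoxy on the aromatic ring, para to a large group, gives a 1.6-fold higher number from compound 2 to compound 4 (0.21 log units; within the scatter). Within the data shown here, this is the first pair differing in one place, and it shows that this read-out does not separate these two groups at this position. Nothing available explains the size of this step.

On these data alone, whether a smaller group such as a plain amine, or a carboxylic acid, at this position would move the number beyond the scatter remains open.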